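The source may hold more compounds than are shown below. What is called first, only, known or untested is meant among the compounds shown, and "the series" means these compounds.

In an ADME assay on HepG2 2.2.15 cells (Homo sapiens) for cytotoxicity, read by CCK-8 assay, with a stated time of 8 days (on this read-out higher numbers stand for lower toxicity in this test and lower numbers for higher toxicity in this test), compound 1 `COc1ccc(-c2cc(NC(=O)c3ccc(OC)cc3O)c[nH]c2=O)cc1` gives 49900 nM, compound 2 `COc1ccc(-c2cc(NC(=O)c3cccc(OC)c3O)c[nH]c2=O)cc1` gives 49200 nM and compound 3 `COc1ccc(-c2cc(NC(=O)c3ccc(C)cc3O)c[nH]c2=O)cc1` gives 46100 nM, so compound 2 stands level with both others. Compound 4 `COc1cccc(C(=O)Nc2c[nH]c(=O)c(-c3cccc(C)c3)c2)c1O` has 3-methylphenyl in place of 4-methoxyphenyl on an aromatic carbon. The nearest evidence is a 1.1-fold lower number from compound 1 to compound 3 (0.03 log units; within the scatter), also a swap of methoxy for methyl but elsewhere in the molecule, and a 1.0-fold lower number from compound 1 to compound 2 (0.01 log units; within the scatter) and a 1.1-fold lower number from compound 2 to compound 3 (0.03 log units; within the scatter) are likewise small. All three lie within the scatter, yet none touches the 4-methoxyphenyl group, so the support is indirect. In this assay the expected change is therefore none beyond the scatter, with a 1.0-fold lower number from compound 2 to compound 4 (0.02 log units; within the scatter) as the estimated step. Compound 4 is estimated at 47000 nM, within a range of 22000 nM to 95000 nM as expected limits.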

Compound 4, half-maximal cytotoxic concentration: > 100000 nM
Compound 4 gave a limit, no number (the forecaster's own chance of this, stated with the estimate: 20%); middle value at least 2.1-fold (0.32 log units) away from the limit.
By their numbers in this assay, from the lowest: compounds 3, 2 and 1 (each within the scatter of the next). At a limit, above all of these: compound 4.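

Among the compounds shown here, compound 1, compound 2 and compound 3 differ only in the group on the carbonyl carbon, so this is the first change at the aromatic carbon two atoms from the ring nitrogen, and in this assay it gives an at least 2.0-fold higher number from compound 2 to compound 4 (0.30 log units; that floor lies within the scatter). Compound 4 stands at a limit, not a number: the limit of > 100000 nM in this assay, at which 1 of the 4 values shown sits. The swap of 4-methoxyphenyl for 3-methylphenyl thus shows no sign of a lower number, though its floor alone does not place it beyond the scatter.

Because methoxy gives way to methyl and the group moves at once, the two changes cannot be separated. From the compounds shown here alone, how an amine or a carboxylic acid on this phenyl ring would read remains open.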